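Bromo for chloro: a halogen swap on a shared core

A few compounds are considered here, and "the series" means these few. Any claim that something is new, unique, unknown or untested is made for them only; others in the source may bear on it.

All three measured compounds were tested in a functional assay on P388 cells (Mus musculus) for inhibition; a lower number here means a stronger inhibitor, a higher number a weaker inhibitor:
Compound 1, `O=C1/C(=C/c2ccccc2Cl)Cc2ccccc21`, gives 26500 nM.
Compound 2, `O=C1/C(=C/c2ccccc2Br)CCc2ccccc21`, gives 19700 nM.
Compound 3, `O=C1/C(=C/c2ccc(Cl)cc2Cl)Cc2ccccc21`, reaches only a limit of the assay, > 50000 nM.

Of the two numbers shown, compound 1 has the higher one, and compound 2 sits nearest to it, a gap that lies within the scatter; the remaining value is a limit. For the measured compounds named here, the only measured step, an at least 1.8-fold higher number from compound 1 to compound 3 (0.27 log units; that floor lies within the scatter), concerns a different change, and its floor lies within the scatter, as noted in the limit of > 50000 nM in this assay, at which 1 of the 3 values shown sits. Compound 4, `O=C1/C(=C/c2ccccc2Br)Cc2ccccc21`, differs from compound 1 by bromo in place of chloro on an aromatic carbon. Going by the values given here, no measured step covers this swap directly, but compound 2 carries the same bromo group on a different core and gives a value within the scatter of compound 1. Compound 4 is therefore expected to show a 1.2-fold lower number from compound 1 to compound 4 (0.06 log units; within the scatter), that is, no step beyond the scatter in this assay. The estimate for compound 4 is 23000 nM, with a range from 10000 nM to 50000 nM.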

Compound 4, half-maximal inhibitory concentration: > 50000 nM
Compound 4: a limit, no number; the forecaster's own chance of this, stated with the estimate: 15%; middle value at least 2.1-fold (0.33 log units) away from the limit.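

In this assay, bromo in place of chloro on this aromatic carbon, ortho to a large group, gives an at least 1.8-fold higher number from compound 1 to compound 4 (0.27 log units; that floor lies within the scatter) on the shared core, so the step's floor does not separate the two compounds. The earlier compounds shown here did not show that this bromo group can yield no number on the core of compound 1, whereas compound 2 gives 19700 nM with the same group on a different core. Compound 4, like compound 3, stands at a limit of the assay and not at a number: the limit of > 50000 nM in this assay, at which 2 of the 4 values shown sit.

Going by these compounds, how far compound 3 and compound 4 lie from that limit stays open, and with it the true size of the bromo step. The compounds shown also leave open how a methoxy group or an amine on this aromatic carbon would read in this assay on the shared core.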